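A few compounds are considered here, and "the series" means these few. Any claim that something is new, unique, unknown or untested is made for them only; others in the source may bear on it.

In an ADME assay on Vero cells (Chlorocebus sabaeus) for cytotoxicity, with a stated time of 3 days (on this read-out lower numbers stand for stronger inhibition and higher numbers for weaker inhibition), compound 1 `O=C(Nc1cc2nc(C3CCCCC3)[nH]c2cc1N1CCCC1)C1CC1` gives > 200 ug/mL, which is a limit of the assay rather than a number. Compound 2 `CCOC(=O)Nc1cc(N)c2[nH]c(-c3ccc(Br)cc3)nc2c1` in this assay likewise gives > 200 ug/mL, again a limit and not a measured number. Compound 2 thus stands at the edge of what this assay reports, and the limit of > 200 ug/mL in this assay, at which 2 of the 2 values shown sit, describes where both values shown sit. Compound 3 `CCOC(=O)Nc1cc(N)c2[nH]c(-c3cc(C)cc(C)c3)nc2c1` is not yet measured in this assay; it differs from compound 2 in one place, (3,5-dimethylphenyl in place of 4-bromophenyl on an aromatic carbon), that is, 3,5-dimethylphenyl in place of 4-bromophenyl on an aromatic carbon. Among the measured compounds shown here, no step between measured compounds in this assay has been set out, so nothing here shows how a change at this place moves the read-out. The step of a number no higher from compound 2 to compound 3 (the limit leaves the size open) is estimated to bring no shift beyond the usual scatter. Compound 3 is therefore expected to give 200 ug/mL in this assay, within a range from 100 ug/mL to 400 ug/mL, most likely again reported only as a limit.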

Compound 3, half-maximal inhibitory concentration: > 200 ug/mL
Compound 3 ended at the assay's limit; the forecaster's own chance of this, stated with the estimate: 80%; the middle value sits exactly at the limit.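

In this assay compound 3 gives > 200 ug/mL, a limit and not a number, as compound 2 does, so no step can be read between compound 2 and compound 3. The compounds shown leave open whether 3,5-dimethylphenyl and 4-bromophenyl differ at all on this read-out.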